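Compound 1 to compound 3: nitrogen substituent exchange

A few compounds are considered here, and "the series" means these few. Any claim that something is new, unique, unknown or untested is made for them only; others in the source may bear on it.

In a functional assay on HEL cells (Homo sapiens) for cytotoxicity (a lower number here means that less compound is tolerated, a higher number that more compound is tolerated), compound 1 (`CCCCC#Cc1cc2cn(C)c(=O)nc2o1`) gives > 217000 nM, which is a limit and not a number. Compound 2 (`CCCCCCCCCCC#Cc1cc2cn(C)c(=O)nc2o1`) gives > 150000 nM, which is also a limit. Compound 1 therefore has no numerical value here to serve as a starting point.

The next compound, compound 3 (`CCCCC#Cc1cc2cn([C@H]3C[C@H](O)[C@@H](CO)O3)c(=O)nc2o1`), keeps the chain of compound 1 and changes the group on the aromatic nitrogen: 4-hydroxy-5-(hydroxymethyl)oxolan-2-yl in place of methyl on an aromatic nitrogen.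

For the measured compounds named here, the only measured step is a step that the two limits leave unreadable from compound 1 to compound 2. It has no readable size, and it lies on the chain, not on the aromatic nitrogen. Going by the values given here, no measured step covers the replacement of methyl by 4-hydroxy-5-(hydroxymethyl)oxolan-2-yl.

Among the compounds with values here, with a step that the two limits leave unreadable from compound 1 to compound 2 as the only guide, no step beyond the scatter is expected in this assay, in either direction, and a further limit is the most likely report. For compound 3, the expected value is 150000 nM, with an estimated range from 50000 nM to 300000 nM. The estimate corresponds to an expected at least 1.4-fold lower number from compound 1 to compound 3 (0.16 log units; that floor lies within the scatter).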

Compound 3, half-maximal cytotoxic concentration: > 150000 nM
Compound 3 gave a limit, no number; the forecaster's own chance of this, stated with the estimate: 75%; the middle value lies on the limit itself.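

Compound 1 and compound 3 both give only a limit, so no step between them can be read: the limit of > 150000 nM in this assay, at which 2 of the 3 values shown sit.

The compounds shown leave open where the half-maximal cytotoxic concentrations of compound 1 and compound 3 lie in this assay, and whether 4-hydroxy-5-(hydroxymethyl)oxolan-2-yl in place of methyl on the aromatic nitrogen changes that read-out at all.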